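The source may hold more compounds than are shown below. What is called first, only, known or untested is meant among the compounds shown, and "the series" means these compounds.

Working notes on a naphthoquinone sulfonamide series tested in a functional assay on HeLa cells (Homo sapiens) for cytotoxicity, read by sulforhodamine B assay; a lower number here means a stronger inhibitor, a higher number a weaker inhibitor.

Compound 1 `CC(=O)c1ccc(S(=O)(=O)NC(C2=CC(=O)c3c(O)ccc(O)c3C2=O)C(C)C)cc1` gives 3820 nM in this assay. Compound 2 `CCOC(=O)c1ccc(S(=O)(=O)NC(C2=CC(=O)c3c(O)ccc(O)c3C2=O)C(C)C)cc1` differs from compound 1 by ethoxy in place of methyl on a carbonyl carbon; in this assay compound 2 gives 850 nM, so a 4.5-fold lower number from compound 1 to compound 2 (0.65 log units; beyond the scatter). Compound 3 `CC(=O)c1ccc(S(=O)(=O)NC(C)C2=CC(=O)c3c(O)ccc(O)c3C2=O)cc1` differs from compound 1 by methyl in place of isopropyl on a saturated chain carbon bound to a double-bonded ring carbon and a sulfonamide nitrogen; in this assay compound 3 gives 5760 nM, and a 1.5-fold higher number from compound 1 to compound 3 (0.18 log units; within the scatter), so compound 1 and compound 3 are not separated. Compound 3 and compound 2 differ in two places, and their values lie apart beyond the scatter.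

Compound 4 `CCOC(=O)c1ccc(S(=O)(=O)NC(C)C2=CC(=O)c3c(O)ccc(O)c3C2=O)cc1` is not yet measured. It differs from compound 3 by ethoxy in place of methyl on a carbonyl carbon, the same kind of change as from compound 1 to compound 2, at a place described in the same words. The cores of compound 3 and compound 4 differ from those of compound 1 and compound 2 by methyl in place of isopropyl on a saturated chain carbon bound to a double-bonded ring carbon and a sulfonamide nitrogen. The step from compound 3 to compound 4 in this assay is expected to be a 3.6-fold lower number from compound 3 to compound 4 (0.56 log units; beyond the scatter), set beside a 4.5-fold lower number from compound 1 to compound 2 (0.65 log units; beyond the scatter) and somewhat damped, because a single precedent with a 4.5-fold lower number from compound 1 to compound 2 (0.65 log units; beyond the scatter) carries limited weight. Compound 4 is estimated at 1600 nM, between 700 nM and 3800 nM.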

Compound 4, half-maximal inhibitory concentration: 2260 nM
The estimate for compound 4 lay 1.4-fold (0.15 log units) below the measured number; the range from low to high includes it.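

In this assay, ethoxy in place of methyl on a carbonyl carbon carries to the second core, giving a 2.5-fold lower number from compound 3 to compound 4 (0.41 log units; beyond the scatter), and the size of this step does not separate from that of the earlier one: the same change on two cores in this assay, a 4.5-fold lower number (0.65 log units; beyond the scatter) from compound 1 to compound 2 and a 2.5-fold lower number (0.41 log units; beyond the scatter) from compound 3 to compound 4, 1.8-fold (0.25 log units) apart, within the scatter of two such steps. Methyl in place of isopropyl on a saturated chain carbon bound to a double-bonded ring carbon and a sulfonamide nitrogen gives a 2.7-fold higher number from compound 2 to compound 4 (0.42 log units; beyond the scatter), which lies beyond the scatter while a 1.5-fold higher number from compound 1 to compound 3 (0.18 log units; within the scatter) does not, yet the two steps are not separated: the same change on two cores in this assay, a 1.5-fold higher number (0.18 log units; within the scatter) from compound 1 to compound 3 and a 2.7-fold higher number (0.42 log units; beyond the scatter) from compound 2 to compound 4, 1.8-fold (0.25 log units) apart, within the scatter of two such steps. These four compounds support carrying each change between these two cores only; they show neither that the steps hold on any other core nor why either change moves the number.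

Still open, on these data alone, is how a carboxylic acid or an amine on the carbonyl carbon, or a longer chain in place of ethoxy, would compare. Also open, as far as these compounds go, is whether a longer chain on the saturated chain carbon would keep these steps.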